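Methoxy in place of methyl on compound 3

A few compounds are considered here, and "the series" means these few. Any claim that something is new, unique, unknown or untested is made for them only; others in the source may bear on it.

Going by the values given here, in a functional assay on MDA-MB-231 cells (Homo sapiens) for cytotoxicity, read by MTT assay, with a stated time of 24 h (on this read-out higher numbers stand for weaker inhibition and lower numbers for stronger inhibition), compound 3 `Cc1ccc(-c2nc3cccnc3n2C2CCCCC2)cc1` gives 7000 nM as the highest of the three numbers measured so far. Compound 1 `Fc1cc(F)cc(C2Nc3cccnc3N2C2CCCC2)c1` gives 2100 nM and compound 2 `Fc1cccc(-c2nc3cccnc3n2C2CCCCC2)c1` gives 342 nM on the same read-out. Compound 4 `COc1ccc(-c2nc3cccnc3n2C2CCCCC2)cc1` has methoxy in place of methyl on an aromatic carbon, para to a large group (methoxy in place of methyl on an aromatic carbon). Among the compounds with values here, the only measured step that bears on this change is a 20-fold higher number from compound 2 to compound 3 (1.31 log units; beyond the scatter) and it is large, but it exchanges a different group, so it offers only weak guidance. The expected change is small, estimated as a 1.4-fold lower number from compound 3 to compound 4 (0.15 log units; within the scatter) and not expected to lie beyond the scatter. The estimated value for compound 4 is 5000 nM (range 1500 nM to 15000 nM).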

Compound 4, half-maximal inhibitory concentration: 112 nM
Beside the measured number, compound 4's estimate is 45-fold (1.65 log units) above it; measured number outside the range, below it.
By their numbers in this assay, from the lowest: compound 4; then compound 2; then compound 1; then compound 3.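

In this assay the step of a 63-fold lower number from compound 3 to compound 4 (1.80 log units; beyond the scatter) shows that this position, on an aromatic carbon para to a large group, is highly sensitive to methoxy in place of methyl, a change that brings in an oxygen and a hydrogen-bond acceptor. The earlier large step changed both the group and its place on the ring, whereas here the place stays fixed and only the group differs. No measurement shown accounts for the size of this step.

The compounds shown leave open whether the oxygen alone carries this effect. Going by these compounds, how a hydroxyl, an ethoxy or an amine would read at this position also remains open.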